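Methyl entering the core of compound 1

The source may hold more compounds than are shown below. What is called first, only, known or untested is meant among the compounds shown, and "the series" means these compounds.

Compound 1 `COc1ccc(/C(Cl)=C/C=C(\C#N)C(=O)c2c[nH]c3ccccc23)cc1` is tested in a functional assay on MCF7 cells (Homo sapiens) for cytotoxicity, read by sulforhodamine B assay, with a stated time of 48 h; on this read-out lower numbers stand for stronger inhibition of growth and higher numbers for weaker inhibition of growth. Compound 1 gives there no number but only a limit, > 100000 nM. Compound 2 `COc1ccc(/C(Cl)=C/C=C(\C#N)C(=O)c2c[nH]c3ccc(Br)cc23)cc1OC` likewise gives only a limit in this assay, > 100000 nM. Compound 3 `COc1cc(/C(Cl)=C/C=C(\C#N)C(=O)c2c[nH]c3ccc(Br)cc23)cc(OC)c1OC` gives 96500 nM in this assay. Among the measured compounds shown here, the single step between measured compounds that differ in one place, an at least 1.0-fold lower number from compound 2 to compound 3 (0.01 log units; that floor lies within the scatter), stays within the scatter, and it concerns methoxy in place of hydrogen on an aromatic carbon, not the change considered here. All three measured values sit at or close to the limit of > 100000 nM in this assay, at which 2 of the 3 values shown sit. Compound 4 `COc1ccc(/C(Cl)=C/C=C(\C#N)C(=O)c2c(C)[nH]c3ccccc23)cc1` differs from compound 1 by methyl in place of hydrogen on an aromatic carbon. For the measured compounds named here, no measured step bears on this change, so nothing points to a move in either direction. Compound 4 is therefore expected to return a limit again in this assay, with the estimated step of a number no higher from compound 1 to compound 4 (the limit leaves the size open) being none beyond the scatter. The expected value for compound 4 is 100000 nM, within a range from 40000 nM to 300000 nM.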

Compound 4, concentration for total growth inhibition: > 100000 nM
Compound 4: only a limit was reported (the forecaster's own chance of this, stated with the estimate: 75%); the middle value lies on the limit itself.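

Compound 1 and compound 4 both return only a limit in this assay, so no step can be read for methyl in place of hydrogen on an aromatic carbon: the limit of > 100000 nM in this assay, at which 3 of the 4 values shown sit.

The compounds shown leave open whether this methyl shifts growth inhibition in either direction.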